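This account rests on a few compounds, and the source may have more. Where it says the series, first, only, none or still open, it means among the compounds named here.

The series shares a core carrying a urea to a substituted phenyl; compound 1 `CC1(C)CC(NC(=O)Nc2ccc(Cl)cc2)c2cc(Br)ccc2O1` and compound 2 `CC1(C)CC(NC(=O)Nc2cccc(Cl)c2)c2cc(Br)ccc2O1` have been measured in a functional assay on T98G cells (Homo sapiens) for inhibition, read by MTT assay, with a stated time of 72 h; on this read-out lower numbers stand for stronger inhibition and higher numbers for weaker inhibition. In this assay compound 1 gives 27000 nM, and compound 2 gives 67000 nM. Among the measured compounds shown here, the only step so far is a 2.5-fold higher number from compound 1 to compound 2 (0.39 log units; beyond the scatter). Compound 1 thus stands lowest of the two numbers, with compound 2 as its nearest neighbour.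

Compound 3 `CC1(C)CC(NC(=O)Nc2ccc(Cl)cc2)c2cc(F)ccc2O1` is not yet measured. Relative to compound 1 it shows (fluoro in place of bromo on an aromatic carbon). For the measured compounds named here, no measured step bears on this change: the single step available concerns the chlorophenyl and leaves the bromo untouched, so it offers no guide to a swap of bromo for fluoro on the core. With nothing to rest on beyond the starting value of compound 1, the expected step is no change at the digits printed from compound 1 to compound 3 (within the scatter), that is, none beyond the scatter, and a wide range to either side is appropriate. The estimate for compound 3 in this assay is 27000 nM, between 9000 nM and 80000 nM.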

Compound 3, half-maximal inhibitory concentration: 30000 nM
Compound 3: middle estimate off by 1.1-fold (0.05 log units), on the low side; the range from low to high includes it.
By their numbers in this assay, from the lowest: compounds 1 and 3 (each within the scatter of the next); then compound 2.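

In this assay, the swap of bromo for fluoro on an aromatic carbon of the shared core gives a 1.1-fold higher number from compound 1 to compound 3 (0.05 log units; within the scatter) and so, with the 4-chlorophenyl held fixed, these two halogens cannot be told apart at this position. The only other step in the series, a 2.5-fold higher number from compound 1 to compound 2 (0.39 log units; beyond the scatter), lies on the chlorophenyl rather than on the core and is beyond the scatter, so among these three compounds a step beyond the scatter is seen only for the chlorophenyl change. No supporting measurement or other information bears on the result.

Going by these compounds, whether this position keeps the same number with something other than a halogen, such as a methoxy group, an amine or a carboxylic acid, remains open, as does the outcome with plain hydrogen in place of the halogen. Also open, on these data alone, is how far the urea link itself can change, for instance to a thiourea or a simple amide, and whether any such change on the core or the link would bring the numbers in this assay substantially lower.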